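The source may hold more compounds than are shown below. What is called first, only, known or untested is meant among the compounds shown, and "the series" means these compounds.

Compound 1 `CCN(CC)CCNC(=O)c1ccc(C(CC)(CC)c2ccc(OCC(=O)C(C)(C)C)c(C)c2)n1CC` is the reference point here. In an assay on HL-60 cells for agonist activity at vitamin D3 receptor (Homo sapiens), read by microscopy, with a stated time of 96 h (a higher number here means that more compound is needed for the effect, a lower number that less compound is needed), compound 1 gives 91 nM, the lowest of the three numbers measured. Compound 2 `CCN(CC)CCNC(=O)c1ccc(C(CC)(CC)c2ccc(OCC(O)C(C)(C)C)c(C)c2)n1CC` gives 110 nM, and a 1.2-fold higher number from compound 1 to compound 2 (0.08 log units; within the scatter). Compound 3 `C#CC(C)OC(=O)c1ccc(C(CC)(CC)c2ccc(OCC(O)C(C)(C)C)c(C)c2)n1CC` gives 200 nM, and a 1.8-fold higher number from compound 2 to compound 3 (0.26 log units; within the scatter). Only the gap from compound 1 to compound 3 lies beyond the scatter, so compound 1 is not clearly apart from compound 2.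

Compound 4 `CCn1c(C(=O)OCc2ccccn2)ccc1C(CC)(CC)c1ccc(OCC(=O)C(C)(C)C)c(C)c1` has not yet been measured in this assay. It differs from compound 1 in one place: (pyridin-2-yl)methoxy in place of (2-(diethylamino)ethyl)amino on a carbonyl carbon. The change sits on a carbonyl carbon whose other neighbour is an aromatic carbon.

For the measured compounds named here, the step that bears on this is the one from compound 2 to compound 3, where the same (2-(diethylamino)ethyl)amino group on the carbonyl carbon gave way to an oxygen-linked group, and that step was a 1.8-fold higher number from compound 2 to compound 3 (0.26 log units; within the scatter), within the scatter. A change of the same kind at the same place in compound 1 is therefore expected to give at most a small step, if any, toward a higher number, with a 1.6-fold higher number from compound 1 to compound 4 (0.22 log units; within the scatter) as the expected size.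

Compound 4 is accordingly estimated at 150 nM in this assay, with a range from 60 nM to 400 nM.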

Compound 4, half-maximal effective concentration: > 50000 nM
Compound 4: no number, only a limit; the forecaster's own chance of this, stated with the estimate: 5%; middle value at least 330-fold (2.52 log units) from the limit.
By their numbers in this assay, from the lowest: compounds 1, 2 and 3 (each within the scatter of the next, the first and the last beyond it). At a limit, above all of these: compound 4.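

In this assay, compound 4 stands only as a limit and not as a number: the limit of > 50000 nM in this assay, at which 1 of the 4 values shown sits. Putting (pyridin-2-yl)methoxy in place of (2-(diethylamino)ethyl)amino on this carbonyl carbon gave an at least 540-fold higher number from compound 1 to compound 4 (2.73 log units; beyond the scatter), whereas the earlier exchange at the same place gave a 1.8-fold higher number from compound 2 to compound 3 (0.26 log units; within the scatter), so this position is far from indifferent to what it carries. An oxygen link on this carbonyl carbon does not settle the outcome by itself: (1-methylprop-2-yn-1-yl)oxy stayed within the scatter and (pyridin-2-yl)methoxy did not, though these two steps start from compounds that differ at the other end, 1-hydroxy-2,2-dimethylpropyl in one and (tert-butyl)carbonyl in the other.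

The compounds shown do not separate the part played by the aromatic ring of (pyridin-2-yl)methoxy from the part played by that other end, nor from the loss of the diethylamino chain itself. A plain benzyloxy group, a carboxylic acid, or an amide built from a (pyridin-2-yl)methyl amine on this carbonyl carbon would each bear on that question.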